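Chloromethylbenzyl purines: amino for chloro in compound 2

The compounds below may be only part of what the source reports. "The series", "measured", "known", "first", "only" and "open" are said of these compounds alone.

Of the compounds shown here, three have been measured in a functional assay on 786-0 cells (Homo sapiens) for cytotoxicity, read by sulforhodamine B assay, with a stated time of 48 h; on this read-out lower numbers stand for stronger inhibition of growth and higher numbers for weaker inhibition of growth. Compound 1 `ClCc1ccc(Cn2cnc3c(Cl)ncnc32)cc1` gives 3980 nM. Compound 2 `ClCc1ccccc1Cn1cnc2c(Cl)nc(Cl)nc21` gives 3470 nM. Compound 3 `ClCc1cccc(Cn2cnc3ncnc(Cl)c32)c1` gives 4070 nM. Compound 2 carries the lowest of the three numbers, yet the gaps to compound 1 and to compound 3 both lie within the scatter, so the three cannot be separated on this read-out.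

Compound 4 `Nc1nc(Cl)c2ncn(Cc3ccccc3CCl)c2n1` is not yet measured. It differs from compound 2 in one place: amino in place of chloro on an aromatic carbon. Among the compounds with values here, no measured pair shows this exchange, so nothing in the data sets the size or direction of the step. With the three measured values all within scatter of one another, the expectation is a step from compound 2 to compound 4 of no more than the scatter, with no clear direction, and the step of a 1.1-fold lower number from compound 2 to compound 4 (0.04 log units; within the scatter) is estimated accordingly. Compound 4 is therefore expected to give about 3200 nM in this assay, within a range from 900 nM to 11000 nM.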

Compound 4, concentration for total growth inhibition: 52500 nM
Compound 4: the middle estimate sits 16-fold (1.22 log units) below what was measured; the measured number lies above the stated range.
By their numbers in this assay, from the lowest: compounds 2, 1 and 3 (each within the scatter of the next); then compound 4.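

In this assay, within the data shown here, the carbon between two ring nitrogen atoms proves sensitive to substitution: amino in place of chloro gives a 15-fold higher number from compound 2 to compound 4 (1.18 log units; beyond the scatter), towards weaker inhibition of growth, and this is the first single-place step. The remaining chloro group and the chloromethylbenzyl part are unchanged, so this step belongs to that one exchange alone. Nothing in hand bears on why the step is so large.

From the compounds shown here alone, whether chloro itself is needed at this carbon, or whether fluoro, methoxy or dimethylamino would keep the number near that of compound 2, remains open. Also open, going by these compounds, is whether the same exchange would have a step of similar size with a hydroxymethyl group in place of the chloromethyl group.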